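The compounds below may be only part of what the source reports. "The series", "measured", "known", "first", "only" and "open" are said of these compounds alone.

Values in a functional assay on PC-3 cells (Homo sapiens) for antiproliferative activity, read by MTT assay, with a stated time of 96 h; a higher number here means a weaker inhibitor, a lower number a stronger inhibitor:
- Compound 1 `FC(F)(F)Oc1cccc(Nc2nnnc3ccc(N4CCC(N5CCCCC5)CC4)nc23)c1`: 5580 nM
- Compound 2 `CC(C)(C)OC(=O)N1CCC(CNc2ccc3nnnc(Nc4cccc(OC(F)(F)F)c4)c3n2)CC1`: > 100000 nM (a limit, not a number)
- Compound 3 `CC(C)N1CCN(c2ccc3nnnc(Nc4cccc(OC(F)(F)F)c4)c3n2)CC1`: 13800 nM

Of the two numeric values, compound 3 at 13800 nM is the higher, so it is the weaker inhibitor of the pair. Compound 1, at 5580 nM, lies lower by more than the usual scatter. Compound 2 gives only a limit of the assay.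

Compound 4 `OCCNc1ccc2nnnc(Nc3cccc(OC(F)(F)F)c3)c2n1` has not yet been measured. It carries (2-hydroxyethyl)amino in place of 4-isopropylpiperazin-1-yl on an aromatic carbon, next to the ring nitrogen: (2-hydroxyethyl)amino in place of 4-isopropylpiperazin-1-yl on an aromatic carbon.

Within the data shown here, no measured pair isolates this change, so the expectation rests on thin ground. The direction expected in this assay is towards a higher number. Among the measured compounds shown here, the main support is compound 2, the only measured compound also attached through an amino nitrogen bearing a hydrogen, which stands at the limit > 100000 nM. Its side chain is very different, so a move all the way to that limit is not assumed. The expected change is a 2.2-fold higher number from compound 3 to compound 4 (0.34 log units; beyond the scatter). For compound 4 the estimated value is 30000 nM, with an expected range of 9000 nM to 90000 nM.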

Compound 4, half-maximal inhibitory concentration: > 100000 nM
Compound 4 ended at the assay's limit; the forecaster's own chance of this, stated with the estimate: 20%; middle value at least 3.3-fold (0.52 log units) away from the limit.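

In this assay, (2-hydroxyethyl)amino in place of 4-isopropylpiperazin-1-yl on this aromatic carbon, next to the ring nitrogen, gives an at least 7.2-fold higher number from compound 3 to compound 4 (0.86 log units; beyond the scatter). Compound 4 gives > 100000 nM, which is a limit of the assay and not a number, so the step marks only the smallest possible size of the change. A side chain with no ring therefore stands at the same limit as compound 2, and among the compounds shown only compound 1 and compound 3, which carry no amino hydrogen at this position, give numbers: the limit of > 100000 nM in this assay, at which 2 of the 4 values shown sit.

The change removes the 4-isopropylpiperazin-1-yl ring and brings in the amino hydrogen and the hydroxyl in a single step, so the compounds shown cannot tell which of these parts goes with the loss of activity. Also open, going by these compounds, is how a morpholin-4-yl ring, or a 2-(dimethylamino)ethylamino chain with a tertiary amine at its end, would read at this position, since either would separate the ring from the terminal amine.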